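A few compounds are considered here, and "the series" means these few. Any claim that something is new, unique, unknown or untested is made for them only; others in the source may bear on it.

Compounds measured in a functional assay on EA.hy 926 cells (Homo sapiens) for cytotoxicity, read by MTT assay, with stated times of 24 h and 12 h; on this read-out higher numbers stand for an effect only at larger amounts of compound and lower numbers for an effect already at smaller amounts:
- compound 1 `CCOC(=O)/C=C/c1ccc(OC(=O)c2nc(C)c(C)nc2C)c(O)c1`: 1700 nM
- compound 2 `CCOC(=O)/C=C/c1ccc(OC(=O)c2nc(C)c(C)nc2C)c(OC)c1`: 38600 nM
- compound 3 `CCOC(=O)/C=C/c1ccc(OC(=O)c2nc(C)c(C)nc2C)cc1`: 34900 nM

Compound 1 has the lowest number of the three. The hydroxy group matters on these numbers, with a 23-fold higher number from compound 1 to compound 2 (1.36 log units; beyond the scatter) on methylating it and a 21-fold higher number from compound 1 to compound 3 (1.31 log units; beyond the scatter) on removing it. Without that hydroxy, the remaining pair shows a 1.1-fold lower number from compound 2 to compound 3 (0.04 log units; within the scatter).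

Compound 4 `Cc1nc(C)c(C(=O)Oc2ccc(/C=C/C(=O)O)cc2O)nc1C` has not yet been measured in this assay. It differs from compound 1 by one change: hydrogen in place of ethyl on an oxygen next to a carbonyl group. The ethoxycarbonyl thus becomes carboxy, and the rest of the structure stays the same.

Among the compounds with values here, none of the measured steps touches this place, since compounds 1, 2 and 3 all carry the ethoxycarbonyl. Within the data shown here, these steps show only that one change in this small set can be large, and they give neither the size nor the direction of this one. Compound 4 keeps the hydroxy group, and compound 1 with that group gives 1700 nM, so a moderate shift towards a higher number is expected, with wide uncertainty. The expected change is a 2.1-fold higher number from compound 1 to compound 4 (0.31 log units; beyond the scatter). For compound 4 the estimated value is 3500 nM, with an expected range from 600 nM to 20000 nM.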

Compound 4, half-maximal effective concentration: 2200 nM
The estimate for compound 4 lay 1.6-fold (0.20 log units) above the measured number; measured number inside the range.
By their numbers in this assay, from the lowest: compounds 1 and 4 (each within the scatter of the next); then compounds 3 and 2 (each within the scatter of the next).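

In this assay, within the data shown here, the ethoxycarbonyl position now has a reading of its own, which the earlier compounds could not give as they all carry that group: hydrogen in place of ethyl on an oxygen next to a carbonyl group gives a 1.3-fold higher number from compound 1 to compound 4 (0.11 log units; within the scatter). With the hydroxy group kept, the change from ethoxycarbonyl to carboxy therefore leaves the number within the scatter, unlike the large steps seen at the hydroxy group, such as a 21-fold higher number from compound 1 to compound 3 (1.31 log units; beyond the scatter). No supporting measurement is available to explain this result.

The compounds shown leave open whether the change from ethoxycarbonyl to carboxy would read the same with the hydroxy group methylated or absent, as in the cores of compound 2 and compound 3. They also leave open how the number would respond to a longer chain than ethyl on that oxygen, such as butyl, or to a primary amide in place of the ester or the carboxylic acid.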